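Chromone ethers: cyclohexyl to pyridinyl at the ring-oxygen carbon

A few compounds are considered here, and "the series" means these few. Any claim that something is new, unique, unknown or untested is made for them only; others in the source may bear on it.

Three compounds of the series have a number in an assay on isolated protein (Cavia porcellus) with Sigma non-opioid intracellular receptor 1 (Homo sapiens) as the target, read by radioligand binding; a lower number here means a stronger inhibitor, a higher number a weaker inhibitor. Compound 2 `O=c1cc(C2CCCCC2)oc2ccc(OCCCCCCN3CCC(O)CC3)cc12` gives 46 nM. Compound 3 `O=c1cc(C2CCCCC2)oc2ccc(OCCCCCCN3CCCCC3)cc12` gives 32 nM; the two cores differ as hydrogen in place of hydroxy on a saturated ring carbon, and the step is a 1.4-fold lower number from compound 2 to compound 3 (0.16 log units; within the scatter). Compound 1 `O=c1cc(-c2cccnc2)oc2ccc(OCCCCCCN3CCC(O)CC3)cc12` gives 210 nM; it differs from compound 2 by pyridin-3-yl in place of cyclohexyl on an aromatic carbon, and that change made a step of a 4.6-fold higher number from compound 2 to compound 1 (0.66 log units; beyond the scatter). Among the three, compound 3 holds the lowest number, but its gap to compound 2 is within the scatter and only the gap to compound 1 is beyond it.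

Compound 4 `O=c1cc(-c2cccnc2)oc2ccc(OCCCCCCN3CCCCC3)cc12` is not yet measured in this assay. Within the data shown here, it differs from compound 3 by pyridin-3-yl in place of cyclohexyl on an aromatic carbon, which is the same change as the one from compound 2 to compound 1, at a place described in the same words. Among the measured compounds shown here, the expectation for compound 4 is therefore a step of about the same size, a 4.7-fold higher number from compound 3 to compound 4 (0.67 log units; beyond the scatter), because the earlier step of a 4.6-fold higher number from compound 2 to compound 1 (0.66 log units; beyond the scatter) is the only guide the series offers. Compound 4 is thus estimated at 150 nM, with a range from 70 nM to 330 nM, and the measurement will show whether the change carries over onto the core of compound 3.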

Compound 4, half-maximal inhibitory concentration: 192 nM
Compound 4: the middle estimate sits 1.3-fold (0.11 log units) below what was measured; the measured number falls inside the stated range.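

In this assay, pyridin-3-yl in place of cyclohexyl gives a 6.0-fold higher number from compound 3 to compound 4 (0.78 log units; beyond the scatter), so the change carries over onto the core without the hydroxy group, and the two readings of it agree: the same change on two cores in this assay, a 4.6-fold higher number (0.66 log units; beyond the scatter) from compound 2 to compound 1 and a 6.0-fold higher number (0.78 log units; beyond the scatter) from compound 3 to compound 4, 1.3-fold (0.12 log units) apart, within the scatter of two such steps

Hydrogen in place of hydroxy gives a 1.1-fold lower number from compound 1 to compound 4 (0.04 log units; within the scatter), and this step also reads alike with either group on the aromatic carbon, so in these four compounds the two changes behave as independent of each other: the same change on two cores in this assay, a 1.4-fold lower number (0.16 log units; within the scatter) from compound 2 to compound 3 and a 1.1-fold lower number (0.04 log units; within the scatter) from compound 1 to compound 4, 1.3-fold (0.12 log units) apart, within the scatter of two such steps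

Among these compounds, this rests on only two cores that differ at a single saturated ring carbon, so it shows nothing about transfer to cores that differ more widely, and it does not explain why pyridin-3-yl gives the higher number.

Open, as far as these compounds go, is whether the step would hold for other groups on that aromatic carbon, such as phenyl or pyridin-4-yl. Also open, from the compounds shown here alone, is whether it would survive a shorter chain to the ring nitrogen, or a carboxylic acid in place of the hydroxy group.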